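The source may report more compounds than this note shows. Statements on the series, on what has been measured and on what is new or still open speak of the compounds shown alone.

Measured so far in a functional assay on Mahlavu cells (Homo sapiens) for antiproliferative activity, read by sulforhodamine B assay, with a stated time of 72 h; a lower number here means a stronger inhibitor, a higher number a weaker inhibitor:

- compound 1, `N#Cc1ccccc1COc1ccc(-c2cc(CN3CCN(Cc4ccc(C(F)(F)F)cc4)CC3)no2)cc1`: 3500 nM
- compound 2, `N#Cc1ccc(COc2ccc(-c3cc(CN4CCN(Cc5ccc(C(F)(F)F)cc5)CC4)no3)cc2)cc1`: 4300 nM

Among the compounds with values here, compound 2 holds the higher of the two numbers in this assay, but its only neighbour is compound 1, and the step of a 1.2-fold higher number from compound 1 to compound 2 (0.09 log units; within the scatter) is within the scatter, so the two compounds read as equal.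

Compound 3, `Fc1cccc(COc2ccc(-c3cc(CN4CCN(Cc5ccc(C(F)(F)F)cc5)CC4)no3)cc2)c1`, arises from compound 2 by 3-fluorophenyl in place of 4-cyanophenyl on a saturated chain carbon bound to an oxygen on an aromatic ring. Within the data shown here, the one measured step, a 1.2-fold higher number from compound 1 to compound 2 (0.09 log units; within the scatter), concerns the same benzylic phenyl and shows that moving the nitrile from 2-cyanophenyl to 4-cyanophenyl left this assay unchanged. Among the measured compounds shown here, no measured step covers removal of the nitrile or entry of a fluorine, so the expectation rests on the indifference of that single step. The step from compound 2 to compound 3 is therefore expected to be small, a 1.1-fold lower number from compound 2 to compound 3 (0.03 log units; within the scatter), with no direction beyond the scatter.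

Compound 3 is estimated at 4000 nM in this assay, within 1500 nM to 11000 nM.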

Compound 3, half-maximal inhibitory concentration: 2900 nM
Beside the measured number, compound 3's estimate is 1.4-fold (0.14 log units) above it; measured number inside the range.
By their numbers in this assay, from the lowest: compounds 3, 1 and 2 (each within the scatter of the next).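

Notes on the group on a saturated chain carbon bound to an oxygen on an aromatic ring, read in this assay: the nitrile is not needed here, since 3-fluorophenyl in place of 4-cyanophenyl gives no step beyond the scatter (a 1.5-fold lower number from compound 2 to compound 3 (0.17 log units; within the scatter)) and the same holds against 2-cyanophenyl (a 1.2-fold lower number from compound 1 to compound 3 (0.08 log units; within the scatter)). The earlier pair showed only that the nitrile could sit in a different ring position, whereas this result covers a change of the substituent itself, with the hydrogen-bond acceptor count of the group going from 1 to 0. No measurement is available that bears on why the three compounds read alike.

Going by these compounds, all three compounds carry a phenyl with one substituent at this place, so the effect of an unsubstituted phenyl, a carboxylic acid or an amine on that ring remains open. On these data alone, whether a longer chain between the oxygen and the ring would also leave the number within the scatter is equally open.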